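Fluoro to methyl at the same ring position

The source may hold more compounds than are shown below. What is called first, only, known or untested is meant among the compounds shown, and "the series" means these compounds.

Compound 2 `CC1=C(/C=C/C(=O)/C=C/c2ccccc2F)C(C)(C)CCC1` in a functional assay on HeLa cells (Homo sapiens) for cytotoxicity, read by sulforhodamine B assay, with a stated time of 48 h (on this read-out lower numbers stand for stronger inhibition and higher numbers for weaker inhibition), gives 41900 nM, while compound 1 `CC1=C(/C=C/C(=O)/C=C/c2ccccc2)C(C)(C)CCC1` gives 70200 nM; the step of a 1.7-fold lower number from compound 1 to compound 2 (0.22 log units; within the scatter) shows the two numbers sitting within the scatter of each other. Compound 3 `CC1=C(/C=C/C(=O)/C=C/c2ccccc2C)C(C)(C)CCC1` carries methyl in place of fluoro on an aromatic carbon. For the measured compounds named here, the only measured step touching this place on the ring, from compound 1 to compound 2, was small, so no shift beyond the scatter is expected here. Compound 3 is therefore estimated at 42000 nM, with a range of 15000 nM to 110000 nM, meaning an expected step of a 1.0-fold higher number from compound 2 to compound 3 (0.00 log units; within the scatter).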

Compound 3, half-maximal inhibitory concentration: > 100000 nM
Compound 3 ended at the assay's limit (the forecaster's own chance of this, stated with the estimate: 5%); middle value at least 2.3-fold (0.37 log units) from the limit.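

In this assay the value of compound 3 is a limit of the assay and not a number: the limit of > 100000 nM in this assay, at which 1 of the 3 values shown sits.

For the compounds shown here, on the aromatic carbon ortho to a large group, methyl in place of fluoro gives an at least 2.3-fold higher number from compound 2 to compound 3 (0.37 log units; beyond the scatter), the first change at this place to pass the scatter. Against hydrogen at the same place, methyl gives an at least 1.4-fold higher number from compound 1 to compound 3 (0.15 log units; that floor lies within the scatter), so it cannot be told whether methyl weakens inhibition relative to hydrogen.

From the compounds shown here alone, whether an amine or a carboxylic acid here would behave like fluoro or like methyl stays open. Going by these compounds, the true value of compound 3 also remains unknown.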